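Removing two methoxy groups, adding one fluorine: compound 4

The compounds below may be only part of what the source reports. "The series", "measured", "known", "first", "only" and "open" are said of these compounds alone.

Three compounds share the same core and differ only in the aromatic ring attached to a nitrogen on an aromatic ring. Compound 1 `Cc1cc(Nc2cc(N3CCN(C)CC3)nc(Nc3ccc(F)c(F)c3)n2)n[nH]1` gives 160 nM in a functional assay on MDA-MB-231 cells (Homo sapiens) for antiproliferative activity, read by CCK-8 assay, with a stated time of 48 h; a lower number here means a stronger inhibitor, a higher number a weaker inhibitor. Compound 2 `Cc1cc(Nc2cc(N3CCN(C)CC3)nc(Nc3ccc(Cl)c(F)c3)n2)n[nH]1` gives 155 nM in this assay, and the step of a 1.0-fold lower number from compound 1 to compound 2 (0.01 log units; within the scatter) shows that this swap changes little. Compound 3 `COc1ccc(Nc2nc(Nc3cc(C)[nH]n3)cc(N3CCN(C)CC3)n2)cc1OC` gives 459 nM in this assay, the highest of the three numbers, lying a 2.9-fold higher number from compound 1 to compound 3 (0.46 log units; beyond the scatter) and a 3.0-fold higher number from compound 2 to compound 3 (0.47 log units; beyond the scatter).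

Compound 4 `Cc1cc(Nc2cc(N3CCN(C)CC3)nc(Nc3cccc(F)c3)n2)n[nH]1` has not yet been measured. The change from compound 3 is 3-fluorophenyl in place of 3,4-dimethoxyphenyl on a nitrogen on an aromatic ring. The two measured steps that bear on it run the other way: replacing a halogenated ring with the dimethoxy ring raised the number by a modest amount in both cases. Going back to a halogenated ring, here with a single fluorine, is therefore expected to lower the number by a similar modest amount, a 2.3-fold lower number from compound 3 to compound 4 (0.36 log units; beyond the scatter). The estimate for compound 4 in this assay is 200 nM, with a range from 90 nM to 450 nM.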

Compound 4, half-maximal inhibitory concentration: 166 nM
Beside the measured number, compound 4's estimate is 1.2-fold (0.08 log units) above it, within the range that was stated.
By their numbers in this assay, from the lowest: compounds 2, 1 and 4 (each within the scatter of the next); then compound 3.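

In this assay the second halogen of the earlier rings proves unnecessary: hydrogen in place of fluoro gives a 1.0-fold higher number from compound 1 to compound 4 (0.02 log units; within the scatter) and hydrogen in place of chloro gives a 1.1-fold higher number from compound 2 to compound 4 (0.03 log units; within the scatter) so compounds 1, 2 and 4 cannot be told apart. A ring carrying a single fluorine therefore does as well as either ring with two halogens. The change from 3,4-dimethoxyphenyl to 3-fluorophenyl gives a 2.8-fold lower number from compound 3 to compound 4 (0.44 log units; beyond the scatter) but it alters the whole ring at once, so it cannot separate the loss of the methoxy groups from the gain of the fluorine.

The compounds shown give no reason for any of these steps. On these data alone, it also remains open whether a phenyl ring with no substituent, or one with a single methoxy or an amine, would group with compound 4 or with compound 3.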